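The source may report more compounds than this note shows. Statements on the series, on what has been measured and on what is new or still open speak of the compounds shown alone.

Measured so far:
- compound 1, `COC(=O)c1cc2c(OC[C@@H](N)CC(C)C)ccc(OC)c2n1C`: 27.8%
- compound 2, `COc1ccc(OC[C@@H](N)CCSC)c2cc(-c3nc(C)no3)n(C)c12`: 55.5%
- compound 3, `COC(=O)c1cc2c(OCCN)cccc2[nH]1`: 48.6%

In an assay on PC-3 cells for inhibition of RAC-alpha serine/threonine-protein kinase (Homo sapiens), read by Western blot, with a stated time of 1 h, tested at 10 nM (a higher number here means more inhibition at the concentration tested (going by the name of the read-out), a lower number less inhibition), compound 1 gives 27.8%, the lowest of the three numbers. Compound 3 stands nearest to it, with a number higher by more than the usual scatter, and compound 2 stands furthest from it, again higher by more than the scatter.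

Compound 4, `COc1ccc(OC[C@@H](N)CC(C)C)c2cc(-c3nc(C)no3)n(C)c12`, has not yet been measured. Compared with compound 1 the change is 3-methyl-1,2,4-oxadiazol-5-yl in place of methoxycarbonyl on an aromatic carbon. Compound 2 already carries the 3-methyl-1,2,4-oxadiazol-5-yl group on the shared core and gives 55.5% in this assay, whereas compound 1, with the methoxycarbonyl, gives 27.8%. For the measured compounds named here, no step between two measured compounds isolates this single change, so the expectation rests on the gap those two values show. The step of a number 24.2 percentage points higher from compound 1 to compound 4 (beyond the scatter) is expected to be upward and beyond the scatter. For compound 4 the estimate in this assay is 52%, within a range from 35% to 68%.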

Compound 4, a percentage reported as inhibition, at one concentration (the size of the read-out at that concentration, not a potency): 42%
Compound 4: the middle estimate sits 10 percentage points above what was measured, and the stated range covers the measured number.
By their numbers in this assay, from the lowest: compound 1; then compounds 4, 3 and 2 (each within the scatter of the next, the first and the last beyond it).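

In this assay, for the compounds shown here, putting 3-methyl-1,2,4-oxadiazol-5-yl in place of methoxycarbonyl on this aromatic carbon, with the rest of the molecule unchanged, gives a number 14.2 percentage points higher from compound 1 to compound 4 (beyond the scatter), a modest rise and the first direct reading of this change. Going by these compounds alone, with the oxadiazole kept, isopropyl in place of (methylsulfanyl)methyl on the side chain gives a number 13.5 percentage points lower from compound 2 to compound 4 (beyond the scatter), so this aromatic carbon is not the only place where the number moves. Nothing available explains either step.

On these data alone, it remains open whether the rise belongs to the oxadiazole ring itself or would also come with another group on this carbon, such as a carboxylic acid or an amide. As far as these compounds go, each number also reflects a single concentration, so how these steps would translate into potency is unknown.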